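The source may report more compounds than this note shows. Statements on the series, on what has been measured and on what is new or still open speak of the compounds shown alone.

Of the compounds shown here, two have numbers so far in a functional assay on A549 cells (Homo sapiens) for antiproliferative activity, read by MTT assay, with a stated time of 48 h; on this read-out lower numbers stand for stronger inhibition and higher numbers for weaker inhibition. In this test compound 1 (`Clc1ccc2[nH]c(-c3cn(-c4ccccc4)nc3-c3ccccc3)nc2c1`) gives 2370 nM, and compound 2 (`Fc1ccc2[nH]c(-c3cn(-c4ccccc4)nc3-c3ccc(Cl)cc3)nc2c1`) gives 4610 nM. These two numbers lie within the usual scatter of each other, so compound 2 stands level with compound 1 and no ranking can be drawn between them.

Compound 3 (`Clc1ccc(-c2nn(-c3ccccc3)cc2-c2nc3cc(Cl)ccc3[nH]2)cc1`) has not yet been measured. It is reached from compound 2 by a single exchange, chloro in place of fluoro on an aromatic carbon, on a six-membered aromatic ring of carbon only that is part of a fused or bridged system of two rings (chloro in place of fluoro on an aromatic carbon). Within the data shown here, no pair of measured compounds isolates a single change, so the data give no direct guide to this one. In this assay, no step beyond the scatter is expected, and no direction can be firmly argued. The estimate is simply set between the value of compound 1, 2370 nM, and that of compound 2, 4610 nM. The expected move is a 1.4-fold lower number from compound 2 to compound 3 (0.15 log units; within the scatter), which stays inside the scatter. For compound 3 the estimated value is 3300 nM, with an expected range from 1400 nM to 7500 nM.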

Compound 3, half-maximal inhibitory concentration: 1340 nM
Compound 3: the middle estimate sits 2.5-fold (0.39 log units) above what was measured; measured number below the stated range.
By their numbers in this assay, from the lowest: compounds 3, 1 and 2 (each within the scatter of the next, the first and the last beyond it).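

In this assay, chloro in place of fluoro on an aromatic carbon of the six-membered carbon ring in the fused two-ring system gives a 3.4-fold lower number from compound 2 to compound 3 (0.54 log units; beyond the scatter), so this position responds to the exchange of one halogen for the other by more than repeat measurements would scatter, a modest step and the only one of that kind shown here. The other single change, the addition of a chloro to an aromatic carbon that otherwise bears hydrogen, gives a 1.8-fold lower number from compound 1 to compound 3 (0.25 log units; within the scatter), which supports no ranking, so with chloro held on the fused system, that added chloro has no readable effect in this assay. Nothing available accounts for the size of the halogen step or says what lies behind it.

On these data alone, whether bromo, a methoxy group or an amine on the same carbon of the fused system would carry the number further down, or back up, remains open. Also open, as far as these compounds go, is whether the exchange of fluoro for chloro would give a step of like size with hydrogen on the aromatic carbon where compound 1 and compound 3 differ.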